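The source may hold more compounds than are shown below. What is called first, only, known or untested is meant among the compounds shown, and "the series" means these compounds.

Measured so far in this series:

Compound 1 `Cn1ncc(Cl)c1-c1cc(C(=O)NC2CNCCC2c2ccc(C(F)(F)F)cc2)oc1Cl`: 7.2 nM
Compound 2 `Cn1ncc(Cl)c1-c1cc(C(=O)N[C@@H]2CN[C@H](CC(O)CO)C[C@H]2c2ccc(Cl)c(Cl)c2)oc1Cl`: 3.79 nM
Compound 3 `CNC(=O)C[C@@H]1C[C@@H](c2ccc(F)c(F)c2)[C@H](NC(=O)c2cc(-c3c(Cl)cnn3C)c(Cl)o2)CN1`: 1.37 nM

All three numbers come from an assay for inhibition of RAC-alpha serine/threonine-protein kinase (Homo sapiens), read by HTRF, with a stated time of 1 h; on this read-out lower numbers stand for stronger inhibition and higher numbers for weaker inhibition. Among them compound 2 stands second highest of the three. Its nearest neighbour is compound 1, whose number is higher but within the scatter, so no order can be read between compound 1 and compound 2. Compound 3 gives a number lower than compound 2 by a margin beyond the scatter.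

The next compound in this line is compound 4 `Cn1ncc(Cl)c1-c1cc(C(=O)N[C@@H]2CN[C@H](CC(=O)NCCO)C[C@H]2c2ccc(Cl)c(Cl)c2)oc1Cl`. It differs from compound 2 in one place: (2-hydroxyethyl)carbamoyl in place of 1,2-dihydroxyethyl on a saturated chain carbon bound to a saturated ring carbon. Going by the values given here, no step between measured compounds matches this change, so the expectation rests only on the three numbers above and on the fact that the change is confined to the chain on the saturated chain carbon bound to a saturated ring carbon, while the rest of the structure of compound 2 is kept.

The step of a 1.3-fold lower number from compound 2 to compound 4 (0.10 log units; within the scatter) is expected to be small, with a slight lean toward a lower number, but not clearly beyond the scatter. Compound 4 is therefore estimated at 3 nM in this assay , with a range from 1.2 nM to 7.5 nM.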

Compound 4, half-maximal inhibitory concentration: 1.41 nM
The estimate for compound 4 lay 2.1-fold (0.33 log units) above the measured number; the measured number falls inside the stated range.
By their numbers in this assay, from the lowest: compounds 3 and 4 (each within the scatter of the next); then compounds 2 and 1 (each within the scatter of the next).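

In this assay, the chain on the saturated chain carbon bound to a saturated ring carbon now has its first readable one-place change: the exchange of 1,2-dihydroxyethyl for (2-hydroxyethyl)carbamoyl gives a 2.7-fold lower number from compound 2 to compound 4 (0.43 log units; beyond the scatter), a modest step but one that clears the scatter. The entering group has 6 heavy atoms against 4 and adds a nitrogen and a double bond, while the counts of hydrogen-bond donors and acceptors stay the same, so at this position the number moves with those counts unchanged and the larger group brings no loss. Nothing measured here accounts for the step.

The compounds shown do not separate the contribution of the carbonyl, the amide hydrogen and the added chain length, and compound 3 differs from compound 4 in more than one place, so it cannot settle this. Also open, from the compounds shown here alone, is how this position responds to a terminal amine, a carboxylic acid or a longer chain in place of the (2-hydroxyethyl)carbamoyl group, with the rest of compound 4 kept.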